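This account rests on a few compounds, and the source may have more. Where it says the series, first, only, none or still open, it means among the compounds named here.

In a functional assay on HeLa cells (Homo sapiens) for inhibition, read by CCK-8 assay, with a stated time of 48 h (a lower number here means a stronger inhibitor, a higher number a weaker inhibitor), compound 1 `COc1ccc(NC(=O)NCCNS(=O)(=O)c2ccc(-c3ccccc3OCc3ccccc3)s2)cc1` gives > 50000 nM, which is a limit and not a number. That places compound 1 at the limit of > 50000 nM in this assay, at which 1 of the 3 values shown sits.

Compound 2 `O=[N+]([O-])c1ccc(NC(=S)NCCNS(=O)(=O)c2ccc(-c3ccccc3OCc3ccccc3)s2)cc1` gives 7100 nM, and compound 3 `O=S(=O)(NCCNC(=S)Nc1ccc(Cl)cc1)c1ccc(-c2ccccc2OCc2ccccc2)s1` gives 7000 nM. Both differ from compound 1 in the group on an amine nitrogen, in an at least 7.0-fold lower number from compound 1 to compound 2 (0.84 log units; beyond the scatter) and an at least 7.1-fold lower number from compound 1 to compound 3 (0.85 log units; beyond the scatter). The step of a 1.0-fold lower number from compound 2 to compound 3 (0.01 log units; within the scatter), chloro in place of nitro on an aromatic carbon, lies within the scatter.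

Compound 4 `COc1ccc(NC(=O)NCCNS(=O)(=O)c2ccc(-c3ccccc3Oc3ccc([N+](=O)[O-])cc3)s2)cc1` keeps that group of compound 1 and changes elsewhere: 4-nitrophenyl in place of benzyl on an oxygen on an aromatic ring. This puts 4-nitrophenyl in place of benzyl on an oxygen on an aromatic ring. For the measured compounds named here, no measured step touches that place, so the gains in an at least 7.0-fold lower number from compound 1 to compound 2 (0.84 log units; beyond the scatter) and an at least 7.1-fold lower number from compound 1 to compound 3 (0.85 log units; beyond the scatter) do not carry over, and the change in this assay is expected to be small, if it can be seen at all. The direction cannot be told from these data, and a further limit is a real possibility. The expected step is an at least 1.2-fold lower number from compound 1 to compound 4 (0.09 log units; that floor lies within the scatter). Compound 4 is estimated at 40000 nM, with an expected range of 15000 nM to 60000 nM.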

Compound 4, half-maximal inhibitory concentration: > 20000 nM
Compound 4: only a limit was reported; the forecaster's own chance of this, stated with the estimate: 55%; the middle value does not contradict the limit.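

In this assay compound 4 gives > 20000 nM, a limit and not a number. Compound 1 also stands only as a limit, so the step between compound 1 and compound 4 cannot be read. The compounds shown leave open whether 4-nitrophenyl in place of benzyl changes the inhibition at all.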